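A few compounds are considered here, and "the series" means these few. Any claim that something is new, unique, unknown or untested is made for them only; others in the source may bear on it.

Values in a functional assay on the whole organism for inhibition, with Scenedesmus acutus as the target; a higher number here means a weaker inhibitor, a lower number a stronger inhibitor:
- compound 1 `COC(=O)c1cc(N2C(=O)C3=C(CCCC3)C2=O)c(F)cc1Cl` gives 67.6 nM
- compound 2 `CCOC(=O)c1cc(N2C(=O)C3=C(CCCC3)C2=O)c(F)cc1Cl` gives 57.5 nM
- compound 3 `CCCOC(=O)c1cc(N2C(=O)C3=C(CCCC3)C2=O)c(F)cc1Cl` gives 33.1 nM

The three compounds share a core and differ only in the chain on an oxygen next to a carbonyl group. Compound 3, at 33.1 nM, sits at the low end of this small set, which means the stronger end in this assay. It cannot be separated from compound 2, as the measured step is a 1.7-fold lower number from compound 2 to compound 3 (0.24 log units; within the scatter). Only the longer comparison, a 2.0-fold lower number from compound 1 to compound 3 (0.31 log units; beyond the scatter), clears the scatter.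

Compound 4 `CC(C)OC(=O)c1cc(N2C(=O)C3=C(CCCC3)C2=O)c(F)cc1Cl` keeps the same atoms but joins them differently: isopropyl in place of propyl on an oxygen next to a carbonyl group. This puts isopropyl in place of propyl on an oxygen next to a carbonyl group. Among the compounds with values here, no measured compound carries isopropyl, so the evidence is indirect. The closest step is a 1.2-fold lower number from compound 1 to compound 2 (0.07 log units; within the scatter), a methyl in place of hydrogen on a saturated chain carbon bound to an oxygen next to a carbonyl group. That step was small, and so was a 1.7-fold lower number from compound 2 to compound 3 (0.24 log units; within the scatter).

The step expected here is therefore also small, and it is estimated as a 1.2-fold higher number from compound 3 to compound 4 (0.08 log units; within the scatter), with no real change beyond the scatter. For compound 4 the estimated value is 40 nM, with an expected range of 18 nM to 90 nM.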

Compound 4, half-maximal inhibitory concentration: 13.8 nM
For compound 4 the middle estimate is 2.9-fold (0.46 log units) above the measured one; measured number outside the range, below it.
By their numbers in this assay, from the lowest: compound 4; then compounds 3, 2 and 1 (each within the scatter of the next, the first and the last beyond it).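

Propyl and isopropyl have the same count of carbon atoms, yet on an oxygen next to a carbonyl group the swap alone moves the number beyond the scatter in this assay (a 2.4-fold lower number from compound 3 to compound 4 (0.38 log units; beyond the scatter)), so how the chain is joined matters here and not just how many atoms it holds. Compound 4 is also clearly separated from the two shorter esters (a 4.2-fold lower number from compound 2 to compound 4 (0.62 log units; beyond the scatter); a 4.9-fold lower number from compound 1 to compound 4 (0.69 log units; beyond the scatter)), which makes it the strongest inhibitor of the four, since all its steps lie beyond the scatter. Nothing available explains why the branched chain gives the lower number.

The compounds shown leave open whether more branching, as in tert-butyl, or a small ring, as in cyclopropyl, on the same oxygen would lower the number further, and whether a longer chain such as butyl would do the same. They also leave open whether the ester link is required at all, since a free carboxylic acid or an amide at this place would test that directly.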